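A few compounds are considered here, and "the series" means these few. Any claim that something is new, unique, unknown or untested is made for them only; others in the source may bear on it.

Measured compounds so far:

Compound 1 `O=C(O)CCCSCCN1C(=O)CC[C@@H]1/C=C/[C@@H](O)Cc1cccc(-c2ccc3[nH]ccc3c2)c1` gives > 10000 nM in an assay on CHO cells for displacement of a labelled ligand from prostaglandin E2 receptor EP3 subtype (Mus musculus), read by scintillation counting, with a stated time of 60 min (on this read-out lower numbers stand for stronger inhibition and higher numbers for weaker inhibition), which is a limit of the assay and not a number.
Compound 2 `O=C(O)CCCSCCN1C(=O)CC[C@@H]1/C=C/[C@@H](O)Cc1cccc(-c2nc3ccccc3s2)c1` gives > 10000 nM in this assay, again a limit rather than a number.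
Compound 3 `O=C(O)c1csc(SCCN2C(=O)CC[C@@H]2/C=C/[C@@H](O)Cc2cccc(-c3nc4ccccc4o3)c2)n1` gives > 10000 nM in this assay, also a limit and not a number.

All three values sit at the same limit (the limit of > 10000 nM in this assay, at which 3 of the 3 values shown sit), so none of them can be placed relative to the others. For the measured compounds named here, the only step between two compounds differing in one place, a step that the two limits leave unreadable from compound 1 to compound 2, is unreadable for that reason. Compound 3 therefore stands at the limit, with no measured number to anchor it.

Compound 4 `Cc1cccc2oc(-c3cccc(C[C@H](O)/C=C/[C@H]4CCC(=O)N4CCSc4nc(C(=O)O)cs4)c3)nc12` differs from compound 3 by methyl in place of hydrogen on an aromatic carbon. Going by the values given here, no measured step bears on this change, and the single measured step is itself unreadable, so there is no basis for expecting a shift beyond the scatter in either direction in this assay. The step of a number no higher from compound 3 to compound 4 (the limit leaves the size open) is expected to be no change. Compound 4 is expected to give 10000 nM, with a range from 3000 nM to 30000 nM, and most likely the assay will again report only a limit.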

Compound 4, inhibition constant: > 10000 nM
Compound 4: a limit, no number (the forecaster's own chance of this, stated with the estimate: 80%); the middle value sits exactly at the limit.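

Compound 3 and compound 4 both give a limit and not a number, so the step between them cannot be read: the limit of > 10000 nM in this assay, at which 4 of the 4 values shown sit.

The compounds shown leave open whether methyl in place of hydrogen has any effect, and which change to the shared core would give a measurable number in this assay.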